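The source may hold more compounds than are shown below. What is called first, only, known or untested is meant among the compounds shown, and "the series" means these compounds.

Compound 1 `CCCCCC(=O)c1ccc(CN(CCCCCCC(=O)O)S(C)(=O)=O)cc1` gives 636 nM in an assay on HEK293 cells for inhibition of prostaglandin E2 receptor EP2 subtype (Rattus norvegicus); on this read-out lower numbers stand for stronger inhibition and higher numbers for weaker inhibition. Compound 2 `CCCCc1ccc(CN(c2ccccc2CCCC(=O)O)S(C)(=O)=O)cc1` gives 494 nM in this assay. Compound 3 `CCCCC(O)c1ccc(CN(CCCCCCC(=O)O)S(C)(=O)=O)cc1` gives 502 nM in this assay.

Compound 3 holds the second highest of the three numbers, but its gaps to compound 2 and to compound 1 are both within the scatter, so no order among the three is established. Within the data shown here, the single measured step, a 1.3-fold lower number from compound 1 to compound 3 (0.10 log units; within the scatter), also stays within the scatter.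

Compound 4 `CS(=O)(=O)N(CCCCCCC(=O)O)Cc1ccc(-c2ccccc2)cc1` differs from compound 3 by phenyl in place of 1-hydroxypentyl on an aromatic carbon. Among the measured compounds shown here, no measured step swaps a 1-hydroxypentyl for a phenyl; the only step on that aromatic carbon, a 1.3-fold lower number from compound 1 to compound 3 (0.10 log units; within the scatter), was within the scatter. The expected step in this assay is therefore a 1.0-fold lower number from compound 3 to compound 4 (0.00 log units; within the scatter), with a wide range. Compound 4 is expected to give 500 nM (range 150 nM to 1700 nM) in this assay.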

Compound 4, half-maximal inhibitory concentration: 289 nM
Beside the measured number, compound 4's estimate is 1.7-fold (0.24 log units) above it, and the stated range covers the measured number.
By their numbers in this assay, from the lowest: compounds 4, 2, 3 and 1 (each within the scatter of the next, the first and the last beyond it).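

On this aromatic carbon, this assay now shows a step beyond the scatter: a 2.2-fold lower number from compound 1 to compound 4 (0.34 log units; beyond the scatter), modest in size, with phenyl in place of pentylcarbonyl. Against 1-hydroxypentyl, phenyl stays within the scatter, at a 1.7-fold lower number from compound 3 to compound 4 (0.24 log units; within the scatter), so phenyl is separated from pentylcarbonyl only. Nothing at hand accounts for either step. Open, going by these compounds, is whether a cyclohexyl or a pyridyl on this carbon would give a similar number, and whether the phenyl swap carries over to the core of compound 2.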